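A few compounds are considered here, and "the series" means these few. Any claim that something is new, unique, unknown or untested is made for them only; others in the source may bear on it.

Compound 2 `CCOC(=O)N1CCC(=NNC(=O)c2ccc(F)cc2)CC1` is evaluated in a functional assay, read by spectrophotometry, with a stated time of 2 h (on this read-out higher numbers stand for weaker inhibition and lower numbers for stronger inhibition), at 74800 nM. Among the compounds with values here, its only measured neighbour is compound 1 `CCOC(=O)N1CCC(=NNC(=O)c2ccc(Cl)cc2)CC1`, which in this assay gives 59000 nM; the step of a 1.3-fold higher number from compound 1 to compound 2 (0.10 log units; within the scatter) is within the scatter, so the two compounds cannot be ordered, and compound 2 simply sits at the higher end of the two numbers. Compound 3 `CCOC(=O)N1CCC(=NNC(=O)c2ccc(C(F)(F)F)cc2)CC1` differs from compound 2 in one place: trifluoromethyl in place of fluoro on an aromatic carbon. Within the data shown here, no measured step covers a trifluoromethyl group, and the single step available, between chloro and fluoro at the same aromatic carbon, moved the number by a 1.3-fold higher number from compound 1 to compound 2 (0.10 log units; within the scatter), which is no more than the scatter. With so little leverage, the expectation for compound 3 is a step of a 1.4-fold lower number from compound 2 to compound 3 (0.13 log units; within the scatter), within the usual scatter of this assay. On that basis compound 3 is estimated at 55000 nM, with a range from 20000 nM to 150000 nM.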

Compound 3, half-maximal inhibitory concentration: 33800 nM
Estimate against measurement, compound 3: 1.6-fold (0.21 log units) above, and the stated range covers the measured number.
By their numbers in this assay, from the lowest: compounds 3, 1 and 2 (each within the scatter of the next, the first and the last beyond it).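

At this place on the aromatic ring, para to a large group, the swap between chloro and fluoro had not separated two compounds, but in this assay trifluoromethyl in place of fluoro gives a modest step beyond the scatter, a 2.2-fold lower number from compound 2 to compound 3 (0.34 log units; beyond the scatter). The same group in place of chloro gives a 1.7-fold lower number from compound 1 to compound 3 (0.24 log units; within the scatter), which lies within the scatter, so the substituent's effect is readable against fluoro only and cannot be read against chloro. Nothing available explains the step from fluoro to trifluoromethyl.

Still open, from the compounds shown here alone, is how a methoxy group, a nitrile or an amine would read at this place, and where the ring with only hydrogen there would stand. Also open, going by these compounds, is whether this step holds when another part of the shared core changes.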